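A few compounds are considered here, and "the series" means these few. Any claim that something is new, unique, unknown or untested is made for them only; others in the source may bear on it.

Compound 1 `ClCc1ccc(Cn2cnc3c(Cl)ncnc32)cc1`: 32400 nM
Compound 2 `ClCc1ccccc1Cn1cnc2c(Cl)nc(Cl)nc21`: 6450 nM

In a functional assay on HOP-62 cells (Homo sapiens) for cytotoxicity, read by sulforhodamine B assay, with a stated time of 48 h (on this read-out lower numbers stand for higher toxicity in this test and higher numbers for lower toxicity in this test), compound 2 gives the lower of the two numbers, 6450 nM, while compound 1 gives 32400 nM, and the gap between them lies beyond the usual scatter. Compound 3 `ClCc1ccccc1Cn1cnc2c(Cl)ncnc21` has not yet been measured in this assay. It differs from compound 2 in one place: hydrogen in place of chloro on an aromatic carbon. Within the data shown here, no pair among the measured compounds shows this single change on its own, so its size cannot be read directly from the data. Among the measured compounds shown here, the only measured compound with a single chloro on the shared core, compound 1, gives the higher of the two numbers, 32400 nM. On that basis the number for compound 3 is expected to rise by a moderate step, a 2.3-fold higher number from compound 2 to compound 3 (0.37 log units; beyond the scatter). Compound 3 is therefore estimated at 15000 nM, with a range from 5000 nM to 45000 nM.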

Compound 3, concentration lethal to 50% of the cells: 20000 nM
The estimate for compound 3 lay 1.3-fold (0.12 log units) below the measured number; measured number inside the range.
By their numbers in this assay, from the lowest: compound 2; then compounds 3 and 1 (each within the scatter of the next).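

In this assay, among these compounds, the swap of chloro for hydrogen on the aromatic carbon between two ring nitrogen atoms gives a 3.1-fold higher number from compound 2 to compound 3 (0.49 log units; beyond the scatter) and so provides the first direct reading of this change on its own. Nothing else differs between these two compounds. The shift beyond the usual scatter belongs to this one place, and in this pair the chloro form goes with higher toxicity in this test. Nothing available here explains why the number moves.

The compounds shown leave open how an amine, a methoxy group or a fluoro group on this carbon would compare with chloro and hydrogen. They also leave open whether the same change would give a step of this size in the framework of compound 1.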